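The source may hold more compounds than are shown below. What is called first, only, known or untested is meant among the compounds shown, and "the series" means these compounds.

Three compounds have been measured in an ADME assay on HepG2 cells (Homo sapiens) for cytotoxicity, read by luminescence, CellTiter-Glo and ATP content, with a stated time of 72 h; on this read-out lower numbers stand for an effect already at smaller amounts and higher numbers for an effect only at larger amounts of compound:

Compound 1 `Fc1ccc(-c2ccc3c(NCCCNCc4ccco4)ccnc3c2)cc1` gives 7760 nM.
Compound 2 `CC(C)CCc1ccc2c(NCCCNCc3ccco3)ccnc2c1` gives 11200 nM.
Compound 3 `COc1ccc(-c2ccc3c(NCCCNCc4ccco4)ccnc3c2)cc1` gives 6000 nM.

Compound 3 has the lowest number of the three in this assay, but its distance to the others is small: the step of a 1.3-fold lower number from compound 1 to compound 3 (0.11 log units; within the scatter) and the step of a 1.9-fold lower number from compound 2 to compound 3 (0.27 log units; within the scatter) both fall within the scatter, so no order among the three can be claimed. The next compound, compound 4 `CC(C)(C)c1ccc(-c2ccc3c(NCCCNCc4ccco4)ccnc3c2)cc1`, differs from compound 3 in one place: tert-butyl in place of methoxy on an aromatic carbon. Within the data shown here, two measured steps touch this position. The step of a 1.3-fold lower number from compound 1 to compound 3 (0.11 log units; within the scatter) exchanges one small group for another on the same aromatic carbon, and the step of a 1.9-fold lower number from compound 2 to compound 3 (0.27 log units; within the scatter) exchanges the whole aromatic arm, yet neither moves the number beyond the scatter. Among the measured compounds shown here, nothing measured so far suggests that a change at this position shifts the read-out, so for compound 4 the expected step is a 1.1-fold higher number from compound 3 to compound 4 (0.03 log units; within the scatter), no larger than the scatter and in no settled direction. The estimate for compound 4 in this assay is 6500 nM, with a range from 3000 nM to 14000 nM.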

Compound 4, half-maximal effective concentration: 3150 nM
Estimate against measurement, compound 4: 2.1-fold (0.31 log units) above, and the stated range covers the measured number.
By their numbers in this assay, from the lowest: compounds 4, 3, 1 and 2 (each within the scatter of the next, the first and the last beyond it).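

Among these compounds, compound 4 brings the first steps at this aromatic carbon that lie beyond the scatter in this assay: a 3.6-fold lower number from compound 2 to compound 4 (0.55 log units; beyond the scatter) and a 2.5-fold lower number from compound 1 to compound 4 (0.39 log units; beyond the scatter), both modest. The direct exchange of methoxy for tert-butyl still stays within the scatter (a 1.9-fold lower number from compound 3 to compound 4 (0.28 log units; within the scatter)), so compound 3 and compound 4 cannot be put in order, and only the comparisons with the fluoro and isopentyl compounds show a real change. Nothing measured here accounts for this result.

The compounds shown leave open whether an amine, a carboxylic acid or a longer chain on this same aromatic carbon would move the number further. They also leave open whether tert-butyl would give a similar step if the side chain on the shared core were different.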